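Adding a Methyl on the Chain: a Cytotoxicity Series

The source may hold more compounds than are shown below. What is called first, only, known or untested is meant among the compounds shown, and "the series" means these compounds.

Compound 1 `CCNC(=O)Nc1cccc(S(=O)(=O)Oc2ccccc2CC)c1` and compound 2 `CCCc1ccccc1OS(=O)(=O)c1cccc(NC(=O)NCC)c1` share one core, while compound 3 `CCNC(=O)Nc1ccc(S(=O)(=O)Nc2ccccc2CC)cc1` is built on another; the difference between the two cores is not broken down here. In a functional assay on M21 cells (Homo sapiens) for cytotoxicity, read by sulforhodamine B assay, with a stated time of 48 h (on this read-out lower numbers stand for stronger inhibition and higher numbers for weaker inhibition), compound 1 gives 30000 nM, and compound 2 gives 25000 nM. The change between them, (methyl in place of hydrogen on a saturated chain carbon, two bonds along the chain from an aromatic carbon), produced a step of a 1.2-fold lower number from compound 1 to compound 2 (0.08 log units; within the scatter). In this assay compound 3 gives 90000 nM, the highest number of the three. Compound 4 `CCCc1ccccc1NS(=O)(=O)c1ccc(NC(=O)NCC)cc1` derives from compound 3 by the same change, (methyl in place of hydrogen on a saturated chain carbon, two bonds along the chain from an aromatic carbon), at the same place. Because the earlier step was a 1.2-fold lower number from compound 1 to compound 2 (0.08 log units; within the scatter), which stayed within the scatter, compound 4 is expected to show a 1.1-fold lower number from compound 3 to compound 4 (0.05 log units; within the scatter). Compound 4 is therefore estimated at 80000 nM, with a likely range from 40000 nM to 160000 nM.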

Compound 4, half-maximal inhibitory concentration: 41000 nM
The estimate for compound 4 lay 2.0-fold (0.29 log units) above the measured number; measured number inside the range.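

In this assay, the change from ethyl to propyl gave a 2.2-fold lower number from compound 3 to compound 4 (0.34 log units; beyond the scatter) while the same change on the other core stayed within the scatter. Set side by side, the two steps do not differ by more than the scatter of two such steps, so the change carries from one core to the other without a measurable difference: the same change on two cores in this assay, a 1.2-fold lower number (0.08 log units; within the scatter) from compound 1 to compound 2 and a 2.2-fold lower number (0.34 log units; beyond the scatter) from compound 3 to compound 4, 1.8-fold (0.26 log units) apart, within the scatter of two such steps This rests on a single pair on each core in one assay, and it does not show that the change would behave alike on any further core.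

The compounds shown leave open whether a longer chain, such as butyl, would extend the step. They also leave open what a hydroxyl or an amine at the same place would do on either core.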